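Aminothiophene series: aryl piperazine ring substitution and cAMP response

The source may hold more compounds than are shown below. What is called first, only, known or untested is meant among the compounds shown, and "the series" means these compounds.

Measured compounds:
compound 1 `CC(C)N1CCN(Cc2csc(N)c2C(=O)c2ccc(Cl)cc2)CC1` — 3.6%
compound 2 `Nc1scc(CN2CCN(c3ccc(F)cc3Cl)CC2)c1C(=O)c1ccc(Cl)cc1` — -6.2%
compound 3 `Nc1scc(CN2CCN(c3ccc(F)cc3F)CC2)c1C(=O)c1ccc(Cl)cc1` — -17%

In a functional assay on CHO cells with adenosine receptor A1 (Homo sapiens) as the target, read by cAMP accumulation and immunoassay, with a stated time of 6 min, tested at 0.1 uM (on this read-out lower numbers stand for a stronger effect and higher numbers for a weaker effect at the one concentration tested), compound 3 gives the lowest of the three numbers. Its nearest neighbour is compound 2, and the step of a number 10.8 percentage points lower from compound 2 to compound 3 (beyond the scatter) is beyond the scatter; the step of a number 20.6 percentage points lower from compound 1 to compound 3 (beyond the scatter) is larger still. Compound 4 `Nc1scc(CN2CCN(c3cccc(F)c3F)CC2)c1C(=O)c1ccc(Cl)cc1` differs from compound 3 by 2,3-difluorophenyl in place of 2,4-difluorophenyl on an amine nitrogen in a ring. Going by the values given here, no measured step moves a fluorine from one ring position to another, so the only guidance is indirect: the step of a number 10.8 percentage points lower from compound 2 to compound 3 (beyond the scatter) shows that changing a halogen on this phenyl ring shifts the number modestly, while a number 9.8 percentage points lower from compound 1 to compound 2 (within the scatter) stays within the scatter. For compound 4 the step of a number 5 percentage points higher from compound 3 to compound 4 (within the scatter) is therefore expected to be small, and compound 4 is estimated at -12% (range -28% to 4%).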

Compound 4, a percentage reported as activity, at one concentration (the size of the read-out at that concentration, not a potency): -5.2%
For compound 4 the middle estimate is 6.8 percentage points below the measured one, and the stated range covers the measured number.
By their numbers in this assay, from the lowest: compound 3; then compounds 2, 4 and 1 (each within the scatter of the next).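

In this assay, the arrangement of the two fluorines alone shifts the number: with the same atoms, a number 11.8 percentage points higher from compound 3 to compound 4 (beyond the scatter), so 2,4-difluorophenyl and 2,3-difluorophenyl are not interchangeable on the ring nitrogen. By contrast, a number 1 percentage points higher from compound 2 to compound 4 (within the scatter) and a number 8.8 percentage points lower from compound 1 to compound 4 (within the scatter), so 2,3-difluorophenyl is not separated from 2-chloro-4-fluorophenyl or isopropyl. Nothing available explains the gap between the two difluorophenyl groups. On these data alone, it remains open how an unsubstituted phenyl or a benzyl group on that nitrogen would compare.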